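From methoxy to oxan-4-yl on the side chain

This account rests on a few compounds, and the source may have more. Where it says the series, first, only, none or still open, it means among the compounds named here.

Measured in a functional assay on PC-3 cells (Homo sapiens) for inhibition, with a stated time of 72 h; on this read-out lower numbers stand for stronger inhibition and higher numbers for weaker inhibition:
Compound 1 `Cc1nc(-c2nc[nH]n2)ccc1-c1cnc2c(n1)N(C(C)C)C(=O)CN2`: 149 nM
Compound 2 `Cc1nc(-c2nc[nH]n2)ccc1-c1cnc2c(n1)N([C@H]1CC[C@H](O)CC1)C(=O)CN2`: 119 nM
Compound 3 `COCCN1C(=O)CNc2ncc(-c3ccc(-c4nc[nH]n4)nc3C)nc21`: 137 nM

Compound 3, at 137 nM, cannot be told apart from the other two compounds. The steps that reach it are a 1.1-fold lower number from compound 1 to compound 3 (0.04 log units; within the scatter) and a 1.2-fold higher number from compound 2 to compound 3 (0.06 log units; within the scatter), and both lie within the scatter.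

Compound 4 `Cc1nc(-c2nc[nH]n2)ccc1-c1cnc2c(n1)N(CCC1CCOCC1)C(=O)CN2` keeps the shared core and carries oxan-4-yl in place of methoxy on a saturated chain carbon, two bonds along the chain from an amide-type nitrogen in a ring. The 2-methoxyethyl group thus becomes 2-(oxan-4-yl)ethyl.

Among the compounds with values here, no measured step makes this exact change. The closest evidence comes from other swaps on the same nitrogen. The step of a 1.3-fold lower number from compound 1 to compound 2 (0.10 log units; within the scatter) brings in 4-hydroxycyclohexyl in place of isopropyl and stays within the scatter, as does a 1.1-fold lower number from compound 1 to compound 3 (0.04 log units; within the scatter). None of the three compounds goes against this flat picture. However, the data hold no ring carried on a chain at this place, so the range is kept wide.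

In this assay, the expected change is no step beyond the scatter, namely a 1.1-fold lower number from compound 3 to compound 4 (0.04 log units; within the scatter). The estimated value for compound 4 is 125 nM, expected to fall between 65 nM and 240 nM.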

Compound 4, half-maximal inhibitory concentration: 34 nM
Compound 4: the middle estimate sits 3.7-fold (0.57 log units) above what was measured; the whole stated range lies above it.
By their numbers in this assay, from the lowest: compound 4; then compounds 2, 3 and 1 (each within the scatter of the next).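

In this assay, the nitrogen substituent had looked flat across isopropyl, 4-hydroxycyclohexyl and 2-methoxyethyl, but this position does respond to the change: a 4.0-fold lower number from compound 3 to compound 4 (0.61 log units; beyond the scatter) is a step beyond the scatter, made by replacing methoxy with oxan-4-yl on a saturated chain carbon. Compound 4 also stands apart from the other two compounds, through a 3.5-fold lower number from compound 2 to compound 4 (0.54 log units; beyond the scatter) and through a 4.4-fold lower number from compound 1 to compound 4 (0.64 log units; beyond the scatter), so it is the most potent of the four on this read-out and the only one to separate from the rest. Methoxy and oxan-4-yl match in their counts of hydrogen-bond donors and acceptors and differ in heavy atoms and in the six-membered ring, but nothing measured here explains why the number falls.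

The compounds shown leave open whether the oxygen of the oxan-4-yl ring matters, which a cyclohexyl group on the same chain, or a piperidin-4-yl group carrying an amine in its place, would address. They also leave open whether a ring is needed at all, or whether a longer open chain such as hexyl would give a similar number.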